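Piperidin-1-yl for diisopropylamino across two cores

A few compounds are considered here, and "the series" means these few. Any claim that something is new, unique, unknown or untested is made for them only; others in the source may bear on it.

Compound 1 `COc1ccc(/C=C/c2nc(NCCN(C(C)C)C(C)C)c3ccccc3n2)cc1OC` and compound 2 `COc1ccc(/C=C/c2nc(NCCN3CCCCC3)c3ccccc3n2)cc1OC` share one core and differ only in the amine at the end of the chain. In a functional assay on A549 cells (Homo sapiens) for cytotoxicity, read by MTT assay, with stated times of 48 h and 4 h (a higher number here means a weaker inhibitor, a lower number a stronger inhibitor), compound 1 gives 38800 nM. In this assay compound 2 gives 82700 nM. The change between them is piperidin-1-yl in place of diisopropylamino on a saturated chain carbon, two bonds along the chain from a nitrogen on an aromatic ring, and the step it made is a 2.1-fold higher number from compound 1 to compound 2 (0.33 log units; beyond the scatter).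

Compound 3 `CC(C)N(CCNc1nc(/C=C/c2ccc([N+](=O)[O-])cc2)nc2ccc(Cl)cc12)C(C)C` carries a different core, and the difference between the two cores is not broken down here. In this assay compound 3 reaches only a limit of the assay, > 100000 nM; this is the limit noted as the limit of > 100000 nM in this assay, at which 1 of the 3 values shown sits. Compound 4 `O=[N+]([O-])c1ccc(/C=C/c2nc(NCCN3CCCCC3)c3cc(Cl)ccc3n2)cc1` is not yet measured. It differs from compound 3 by piperidin-1-yl in place of diisopropylamino on a saturated chain carbon, two bonds along the chain from a nitrogen on an aromatic ring, the same change as from compound 1 to compound 2, at the same place on the chain.

Since the measured step on the first core weakened inhibition beyond the scatter, the expectation for compound 4 in this assay is a step in the same direction, a step that the limit leaves unreadable from compound 3 to compound 4, starting from a limit. Compound 4 is therefore expected at about 200000 nM, with a range of 100000 nM to 500000 nM, and most likely only a limit will be reported.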

Compound 4, half-maximal inhibitory concentration: 41100 nM
Compound 4: middle estimate off by 4.9-fold (0.69 log units), on the high side, outside the stated range (below it).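

In this assay, piperidin-1-yl in place of diisopropylamino gives an at least 2.4-fold lower number from compound 3 to compound 4 (0.38 log units; beyond the scatter), against a 2.1-fold higher number from compound 1 to compound 2 (0.33 log units; beyond the scatter), so the same change runs in opposite directions on the two cores. The step therefore does not carry from the core of compound 1 to the core of compound 3, and a measured step on one core is a poor guide to the other in this series: the same change on two cores in this assay, a 2.1-fold higher number (0.33 log units; beyond the scatter) from compound 1 to compound 2 and an at least 2.4-fold lower number (0.38 log units; beyond the scatter) from compound 3 to compound 4, at least 5.1-fold (0.71 log units) apart, beyond the scatter of two such steps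
Compound 3 gives only a limit of the assay, > 100000 nM, so the full size of its step stays unread and the direction rests on that limit: the limit of > 100000 nM in this assay, at which 1 of the 4 values shown sits.

The compounds shown do not settle which part of the difference between the two cores goes with the reversal, and one pair on each core gives no reason for it. Also open, going by these compounds, is whether another amine such as morpholine, or a longer chain in place of 2-(piperidin-1-yl)ethyl, would follow the pattern of compound 1 and compound 2 or that of compound 3 and compound 4.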